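Fluorine on the pendant phenyl ring: one change, two cores

This account rests on a few compounds, and the source may have more. Where it says the series, first, only, none or still open, it means among the compounds named here.

Compound 1 `Cc1nc(-c2ccccc2)sc1COc1ccc(S(=O)(=O)CC(=O)O)cc1` and compound 2 `Cc1nc(-c2ccc(F)cc2)sc1COc1ccc(S(=O)(=O)CC(=O)O)cc1` share a core and differ only by the change (fluoro in place of hydrogen on an aromatic carbon). In an assay on CHO cells for agonist activity at Free fatty acid receptor 1 (Homo sapiens), read by FLIPR (on this read-out lower numbers stand for an effect already at smaller amounts and higher numbers for an effect only at larger amounts of compound), compound 1 gives 370 nM and compound 2 gives 253 nM, so the change brought a 1.5-fold lower number from compound 1 to compound 2 (0.17 log units; within the scatter). Compound 3 `Cc1nc(-c2ccccc2)sc1COc1ccc2c(c1)OCC2CC(=O)O` carries the same pendant ring on a different core; the difference between the two cores is not broken down here. In this assay compound 3 gives 102 nM, the lowest of the three numbers. Compound 4 `Cc1nc(-c2ccc(F)cc2)sc1COc1ccc2c(c1)OCC2CC(=O)O` is compound 3 with the change (fluoro in place of hydrogen on an aromatic carbon), the same change that turned compound 1 into compound 2, at the same place on the ring. Because the earlier step was a 1.5-fold lower number from compound 1 to compound 2 (0.17 log units; within the scatter), the step from compound 3 to compound 4 is expected to be about as small, a 1.5-fold lower number from compound 3 to compound 4 (0.16 log units; within the scatter), with a fair chance that it is not seen at all. Compound 4 is therefore estimated at 70 nM in this assay, most likely between 35 nM and 140 nM.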

Compound 4, half-maximal effective concentration: 79 nM
Beside the measured number, compound 4's estimate is 1.1-fold (0.05 log units) below it; the range from low to high includes it.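

In this assay, going from phenyl to 4-fluorophenyl on the core of compound 3 gives a 1.3-fold lower number from compound 3 to compound 4 (0.11 log units; within the scatter). Set beside the same change on the core of compound 1, the two steps agree: the same change on two cores in this assay, a 1.5-fold lower number (0.17 log units; within the scatter) from compound 1 to compound 2 and a 1.3-fold lower number (0.11 log units; within the scatter) from compound 3 to compound 4, 1.1-fold (0.05 log units) apart, within the scatter of two such steps. This shows that the change carries over between these two cores in a limited sense, as a small step on each, but it does not show that fluoro has a real effect on either core: both steps lie within the scatter, and two pairs of compounds set no rule for any further core.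

The compounds shown leave open whether another group at the same place on the ring, such as chloro, methyl, trifluoromethyl or an amine, would give a step that stands clear of the scatter. As far as these compounds go, it also remains open whether the small fluoro step would appear again on a third core.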